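This account rests on a few compounds, and the source may have more. Where it says the series, first, only, none or still open, it means among the compounds named here.

The measured compounds in an ADME assay on HCT-116 cells (Homo sapiens) for cytotoxicity, read by CellTiter-Glo, with a stated time of 72 h; a lower number here means a stronger inhibitor, a higher number a weaker inhibitor:
Compound 1 `Cc1noc(C)c1S(=O)(=O)N1CCC(N2CCC(C)CC2)CC1` gives > 10000 nM, which is a limit.
Compound 2 `CC1CCN(C2CCN(S(=O)(=O)c3cccc(-c4ccc(Cl)cc4)c3)CC2)CC1` gives > 5000 nM, also a limit.
Compound 3 `Cc1cc(C)cc(-c2cccc(S(=O)(=O)N3CCC(N4CCC(C)CC4)CC3)c2)c1` gives > 5000 nM, again a limit.

Compound 3 thus stands at the limit of > 5000 nM in this assay, at which 2 of the 3 values shown sit, with no number of its own. Going by the values given here, the single measured step, a step that the two limits leave unreadable from compound 2 to compound 3, is hidden by the two limits and so gives no reading of size or direction. Compound 4 `Cc1cccc(S(=O)(=O)N2CCC(N3CCC(C)CC3)CC2)c1` differs from compound 3 by methyl in place of 3,5-dimethylphenyl on an aromatic carbon. Among the compounds with values here, no measured step bears on this change, and none of the three values shown reaches a number. Compound 4 is therefore expected to give 20000 nM in this assay, within 5000 nM to 100000 nM, most likely reported once more as a limit. The expected step is a step that the limit leaves unreadable from compound 3 to compound 4, which is not expected to reach beyond the scatter in either direction.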

Compound 4, half-maximal inhibitory concentration: > 5000 nM
Compound 4 ended at the assay's limit (the forecaster's own chance of this, stated with the estimate: 85%); the middle value is on the limit's open side.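

Going by these compounds alone, compound 4, like compound 1, compound 2 and compound 3, sits at a limit, so no step among them can be read. The compounds shown leave open whether any group on the sulfonyl sulfur gives a measured number in this assay.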